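The compounds below may be only part of what the source reports. "The series", "measured", "known", "first", "only" and "open" are said of these compounds alone.

Measured in a functional assay on U-373MG ATCC cells (Homo sapiens) for inhibition, read by MTT assay, with a stated time of 72 h; a lower number here means a stronger inhibitor, a higher number a weaker inhibitor:
Compound 1 `CC1(C)CC(NC(=S)NCc2ccccc2)c2cc(F)ccc2O1`: 27000 nM
Compound 2 `CC1(C)CC(NC(=S)Nc2cccc([N+](=O)[O-])c2)c2cc(Br)ccc2O1`: 4000 nM
Compound 3 `CC1(C)CC(NC(=S)Nc2cccc(Cl)c2)c2cc(Br)ccc2O1`: 8000 nM

Compound 3, at 8000 nM, sits within the scatter of compound 2, while compound 1 shows a clearly higher number. Compound 4 `CC1(C)CC(NC(=S)NCc2ccccc2)c2cc(Br)ccc2O1` keeps the core of compound 3 but has benzyl in place of 3-chlorophenyl on an amide-type nitrogen. Among the compounds with values here, the only measured step, a 2.0-fold higher number from compound 2 to compound 3 (0.30 log units; within the scatter), puts chloro in place of nitro on an aromatic carbon, stays within the scatter and does not cover this change. Compound 1 also carries benzyl, but its core differs, which makes its 27000 nM only a loose guide. A moderate move to a higher number in this assay is therefore expected, with an estimated step of a 1.9-fold higher number from compound 3 to compound 4 (0.27 log units; within the scatter). Compound 4 is estimated at 15000 nM, with an expected range from 6000 nM to 35000 nM.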

Compound 4, half-maximal inhibitory concentration: 29000 nM
Compound 4: middle estimate off by 1.9-fold (0.29 log units), on the low side, and the stated range covers the measured number.
By their numbers in this assay, from the lowest: compounds 2 and 3 (each within the scatter of the next); then compounds 1 and 4 (each within the scatter of the next).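

In this assay, benzyl in place of 3-chlorophenyl on an amide-type nitrogen gives a 3.6-fold higher number from compound 3 to compound 4 (0.56 log units; beyond the scatter) and so moves the number beyond the scatter, which the earlier swap of nitro for chloro on the aromatic ring did not do. With benzyl in place, bromo in place of fluoro on an aromatic carbon gives a 1.1-fold higher number from compound 1 to compound 4 (0.03 log units; within the scatter) and so makes no clear difference. No evidence here explains either result. Still open, as far as these compounds go, is how a longer chain, such as 2-phenylethyl, would behave on this nitrogen, and whether an amine on the 3-chlorophenyl ring would change the number.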